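Hydroxyl placement on the aryl ring: series notes

This account rests on a few compounds, and the source may have more. Where it says the series, first, only, none or still open, it means among the compounds named here.

Measured so far in an assay for inhibition of NADPH oxidase 1 (Homo sapiens), read by chemiluminescence; on this read-out higher numbers stand for weaker inhibition and lower numbers for stronger inhibition:

compound 1 `CCc1ccc(N2C(=O)/C(=C/c3ccc(O)cc3O)N(C)C2=S)cc1` gives 8400 nM
compound 2 `CCc1ccc(N2C(=O)/C(=C/c3cccc(O)c3O)N(C)C2=S)cc1` gives 27900 nM
compound 3 `CN1C(=S)N(c2ccc3c(c2)CCC3)C(=O)/C1=C/c1ccc(O)cc1O` gives 6580 nM

Compounds 1 and 2 share one core and differ only in the aryl group: 2,3-dihydroxyphenyl in place of 2,4-dihydroxyphenyl on a double-bonded chain carbon bound to a double-bonded ring carbon. In this assay this gives a 3.3-fold higher number from compound 1 to compound 2 (0.52 log units; beyond the scatter), so the change weakens inhibition by a modest but real margin.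

Compound 3 carries a different core; the difference between the two cores is not broken down here. Its number is the lowest of the three, but against compound 1 it lies within the scatter, so no order between compound 3 and compound 1 can be read. Against compound 2 the gap is beyond the scatter, and the two values show compound 3 as the stronger inhibitor of that pair.

Compound 4 `CN1C(=S)N(c2ccc3c(c2)CCC3)C(=O)/C1=C/c1cccc(O)c1O` is not yet measured. It stands to compound 3 as compound 2 stands to compound 1: 2,3-dihydroxyphenyl in place of 2,4-dihydroxyphenyl on a double-bonded chain carbon bound to a double-bonded ring carbon, the same change at the same place. Among the measured compounds shown here, only one earlier instance of this change exists, on a different core, so the transfer is uncertain.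

For compound 4 in this assay the expected step is a 3.2-fold higher number from compound 3 to compound 4 (0.50 log units; beyond the scatter), set beside the earlier 3.3-fold higher number from compound 1 to compound 2 (0.52 log units; beyond the scatter), resting on the move from compound 1 to compound 2. The estimate for compound 4 is 21000 nM, expected to lie between 9000 nM and 50000 nM.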

Compound 4, inhibition constant: 6630 nM
For compound 4 the middle estimate is 3.2-fold (0.50 log units) above the measured one; the whole stated range lies above it.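

In this assay, replacing 2,4-dihydroxyphenyl with 2,3-dihydroxyphenyl on a double-bonded chain carbon bound to a double-bonded ring carbon gives a 1.0-fold higher number from compound 3 to compound 4 (0.00 log units; within the scatter), so no shift from this change can be read on the core of compound 3. The step seen on the core of compound 1 therefore did not carry over unchanged, and the two steps differ by more than repeated measurements would explain: the same change on two cores in this assay, a 3.3-fold higher number (0.52 log units; beyond the scatter) from compound 1 to compound 2 and a 1.0-fold higher number (0.00 log units; within the scatter) from compound 3 to compound 4, 3.3-fold (0.52 log units) apart, beyond the scatter of two such steps This shows that, in these two matched pairs, the effect of the change depends on the core it sits on, so a step measured on one core is a poor guide to the other; it does not show which part of the core is responsible, why the steps differ, or how the change would behave on any third core, and two pairs support no general rule for the series.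

From the compounds shown here alone, it remains open which of the two outcomes would be more typical on further cores carrying this pair of aryl groups. Also open, going by these compounds, is whether a methoxy group in place of either hydroxyl, or a carboxylic acid on the aryl ring, would show the same dependence on the core.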